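This account rests on a few compounds, and the source may have more. Where it says the series, first, only, none or still open, it means among the compounds named here.

Notes on the series. Within the data shown here, the two measured members share one core, seen in compound 1 `Fc1ccc(/C=N/NC(=S)Nc2nc3ccc(Cl)cc3s2)cc1` and compound 2 `CC(C)(C)NCC(=O)Nc1nc2ccc(Cl)cc2s1`. In a functional assay on the whole organism with Mus musculus as the target, in the maximal electroshock model, with a stated time of 0.5 h (a higher number here means that more compound is needed for the effect, a lower number that less compound is needed), compound 1 gives 30 mg/kg. In this assay compound 2 gives 30 mg/kg. Compound 2 thus stands level with compound 1 at the digits shown; the two values lie within the scatter of each other, so nothing separates them on the numbers, and no order between them can be stated. Among the measured compounds shown here, only two measured points exist, and no pair of measured compounds differing in a single place is available, so the bearing of any one change on the read-out is not yet known from this series.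

The next member, compound 3 `O=C(CN1CCCCC1)Nc1nc2ccc(Cl)cc2s1`, differs from compound 2 in one place: piperidin-1-yl in place of (tert-butyl)amino on a saturated chain carbon bound to a carbonyl carbon. For the measured compounds named here, no measured step of this kind exists here, so the expectation rests on the two values alone, which sit together. The expected step is no change at the digits printed from compound 2 to compound 3 (within the scatter) in this assay, none beyond the scatter. Compound 3 is accordingly estimated at 30 mg/kg in this assay, with a range from 10 mg/kg to 100 mg/kg.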

Compound 3, minimum effective dose: 30 mg/kg
For compound 3 middle estimate and measured number coincide at the digits printed; measured number inside the range.
By their numbers in this assay, from the lowest: compounds 1, 2 and 3 (each within the scatter of the next).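

The series now holds its first step in one place: in this assay, piperidin-1-yl in place of (tert-butyl)amino on a saturated chain carbon bound to a carbonyl carbon gives no change at the digits printed from compound 2 to compound 3 (within the scatter). At this position, then, a group with one six-membered non-aromatic ring and 0 hydrogen-bond donors reads the same as an open group with no ring and 1 hydrogen-bond donor, so neither difference between these two groups shows up in the minimum effective dose. No measured property of either group is available to account for this result.

Going by these compounds, whether the same holds for other groups on this carbon, such as morpholin-4-yl, a primary amine or a carboxylic acid, stays open, as does the effect of a longer chain in place of the single saturated carbon. This reading also rests on one pair of compounds, so it cannot yet be carried over to the thiourea-bearing side of compound 1, which differs from both of the others in more than one place.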